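Two Selenium Chains in Place of One Amino Group

The source may hold more compounds than are shown below. What is called first, only, known or untested is meant among the compounds shown, and "the series" means these compounds.

Measured so far:
compound 1 `CCCCC[Se]c1nc(N)c2ccccc2n1` — 28600 nM
compound 2 `C[Se]c1nc(N)c2ccccc2n1` — 46500 nM

In a functional assay on MCF7 cells (Homo sapiens) for cytotoxicity, read by MTT assay, with a stated time of 72 h (a lower number here means a stronger inhibitor of growth, a higher number a weaker inhibitor of growth), compound 1 gives 28600 nM, the lowest of the two numbers shown; compound 2 gives 46500 nM, and the step of a 1.6-fold higher number from compound 1 to compound 2 (0.21 log units; within the scatter) is within the scatter. Compound 3 `CCCCC[Se]c1nc([Se]CCCCC)c2ccccc2n1` differs from compound 1 by a group of 6 heavy atoms (5 carbon, 1 selenium; no ring) in place of one nitrogen atom, on an aromatic carbon. No measured step touches the amino group, so nothing shown predicts the direction of this change; the one step known, a 1.6-fold higher number from compound 1 to compound 2 (0.21 log units; within the scatter), only says that lengthening the chain bound to selenium did little. Compound 3 is therefore expected to stay near compound 1, with a step of a 1.0-fold higher number from compound 1 to compound 3 (0.02 log units; within the scatter), and its estimated value is 30000 nM with a range from 10000 nM to 100000 nM.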

Compound 3, concentration for 50% growth inhibition: 38400 nM
Compound 3: middle estimate off by 1.3-fold (0.11 log units), on the low side; the range from low to high includes it.
By their numbers in this assay, from the lowest: compounds 1, 3 and 2 (each within the scatter of the next).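

Replacing the amino group on this aromatic carbon with a group of 6 heavy atoms (5 carbon, 1 selenium; no ring) gives a 1.3-fold higher number from compound 1 to compound 3 (0.13 log units; within the scatter) in this assay. This position therefore tolerates the loss of the amino group's hydrogen-bond donor and the entry of a much larger chain without a change that can be read in this assay. Nothing measured here explains this result. As far as these compounds go, it remains open whether an amine bearing a longer chain or a carboxylic acid at this position would move the number beyond the scatter.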